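A few compounds are considered here, and "the series" means these few. Any claim that something is new, unique, unknown or untested is made for them only; others in the source may bear on it.

In a physicochemical assay for solubility, read by chemiluminescence, measured as kinetic solubility (on this read-out lower numbers stand for lower solubility and higher numbers for higher solubility), compound 2 `O=C(C1CCCCC1)N1CCC2(CCN(c3nccc(NCc4ccc(Cl)cc4Cl)n3)CC2)C1` gives 3 ug/mL as the lower of the two numbers, and compound 1 `O=C([C@@H]1CCCN1)N1CCC2(CCN(c3nccc(NCc4ccc(Cl)cc4Cl)n3)CC2)C1` gives 165 ug/mL as the higher. Compound 3 `O=C(C1COCCN1)N1CCC2(CCN(c3nccc(NCc4ccc(Cl)cc4Cl)n3)CC2)C1` differs from compound 2 morpholin-3-yl in place of cyclohexyl on a carbonyl carbon in carrying morpholin-3-yl in place of cyclohexyl on a carbonyl carbon. Among the measured compounds shown here, the one measured step that bears on this change, a 55-fold lower number from compound 1 to compound 2 (1.74 log units; beyond the scatter) with cyclohexyl in place of pyrrolidin-2-yl, was large and beyond the scatter. With that step as the guide, a large rise in this assay is expected, an estimated 37-fold higher number from compound 2 to compound 3 (1.56 log units; beyond the scatter) in size. Compound 3 is estimated at 110 ug/mL within a range of 35 ug/mL to 300 ug/mL on this read-out.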

Compound 3, solubility: 233 ug/mL
Beside the measured number, compound 3's estimate is 2.1-fold (0.33 log units) below it; the range from low to high includes it.
By their numbers in this assay, from the lowest: compound 2; then compounds 1 and 3 (each within the scatter of the next).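

In this assay, a second ring with hetero atoms, morpholin-3-yl, also stands far from cyclohexyl on this carbonyl carbon, with a 78-fold higher number from compound 2 to compound 3 (1.89 log units; beyond the scatter) as the step. Set against pyrrolidin-2-yl, morpholin-3-yl gives a 1.4-fold higher number from compound 1 to compound 3 (0.15 log units; within the scatter), so the large gap from cyclohexyl is no longer tied to a single group. Nothing available accounts for this gap. On these data alone, how tetrahydropyranyl, with a ring oxygen and no ring nitrogen, or an open-chain amine would read on the same carbonyl carbon remains open.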